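This account rests on a few compounds, and the source may have more. Where it says the series, first, only, none or still open, it means among the compounds named here.

Measured so far:
- Compound 1, `COc1ccc(-c2ccc(-c3ccc(C(=N)N)o3)o2)cc1`: in an ADME assay on cells (Erythrocyte, Homo sapiens) for activation, read by hemolysis, with a stated time of 30 min, tested at 1.25 mM (on this read-out higher numbers stand for a stronger effect at the one concentration tested and lower numbers for a weaker effect), compound 1 is reported as "non-toxic" (no number reported), with no number attached.
- Compound 2, `COc1cccc(-c2ccc(-c3ccc(C(=N)N)s3)s2)c1`: compound 2 gives 3.1%.

Compound 1 therefore stands without a single number; it is known only as non-toxic. Compound 3, `N=C(N)c1ccc(-c2ccc(-c3ccccc3)o2)o1`, differs from compound 1 in one place: hydrogen in place of methoxy on an aromatic carbon. Among the compounds with values here, no step between two measured compounds is available to gauge the size of such a change. Since compound 2 sits low at 3.1% and compound 1 is called non-toxic, the step in this assay is expected to stay within the usual scatter, with no clear direction. Compound 3 is estimated to give about 3%, most likely between 0% and 12%.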

Compound 3, a percentage reported as activity, at one concentration (the size of the read-out at that concentration, not a potency): "non-toxic" (no number reported)
The entry for compound 3 holds no number, and the estimate cannot be compared.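

Compound 1 and compound 3 are both reported only as non-toxic, with no number, so no step can be read between them. No other data bear on this result. On these data alone, whether replacing methoxy with hydrogen changes hemolysis, and by how much, remains open.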